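Notes on changing the group on the carbonyl carbon

The compounds below may be only part of what the source reports. "The series", "measured", "known", "first", "only" and "open" are said of these compounds alone.

Measured so far in a functional assay on A549 cells (Homo sapiens) for inhibition, read by MTT assay, with a stated time of 24 h; on this read-out lower numbers stand for stronger inhibition of growth and higher numbers for weaker inhibition of growth:
- compound 1 `COc1cccc(C(=O)n2c(-c3cn(C)c4ccccc34)nc3ccccc32)c1` gives 10200 nM
- compound 2 `COc1ccc(C(=O)n2c(-c3cn(C)c4ccccc34)nc3ccccc32)cc1` gives 10400 nM
- compound 3 `COc1ccc(C(=O)n2c(-c3cn(C)c4ccc(OC)cc34)nc3ccccc32)cc1` gives 4900 nM

Compound 3 has the lowest number of the three, and it lies beyond the scatter from both compound 1 and compound 2. Compound 4 `COc1ccc2c(c1)c(-c1nc3ccccc3n1C(=O)c1cccc(Br)c1)cn2C` differs from compound 3 by one change, 3-bromophenyl in place of 4-methoxyphenyl on a carbonyl carbon. For the measured compounds named here, the one measured step at this carbonyl substituent, a 1.0-fold higher number from compound 1 to compound 2 (0.01 log units; within the scatter), stays within the scatter, though it only alters the methoxy arrangement. Going by the values given here, no measured compound carries bromine, so the evidence for the new group is thin. The other step, a 2.1-fold lower number from compound 2 to compound 3 (0.33 log units; beyond the scatter), is modest and concerns a different place. Its added methoxy is retained in compound 4, which makes compound 3 the proper reference. No change beyond the scatter is therefore expected, and no direction is favoured with any confidence. The expected change is a 1.0-fold higher number from compound 3 to compound 4 (0.01 log units; within the scatter) in this assay as estimated here. The estimate for compound 4 is 5000 nM, with the value expected between 2200 nM and 11500 nM in this assay as the likely range.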

Compound 4, concentration for 50% growth inhibition: 24800 nM
Estimate against measurement, compound 4: 5.0-fold (0.70 log units) below; the whole stated range lies below it.
By their numbers in this assay, from the lowest: compound 3; then compounds 1 and 2 (each within the scatter of the next); then compound 4.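

In this assay, exchanging 4-methoxyphenyl for 3-bromophenyl on the carbonyl carbon gives a 5.1-fold higher number from compound 3 to compound 4 (0.70 log units; beyond the scatter) and so shows that this position responds to the group it carries, which the earlier 1.0-fold higher number from compound 1 to compound 2 (0.01 log units; within the scatter) within the methoxyphenyl pair did not show. The move is towards weaker inhibition of growth, so with the core of compound 3 held fixed, 4-methoxyphenyl reads better than 3-bromophenyl, and the position cannot be treated as tolerant of any aromatic group. Nothing available accounts for this step, so it stands as an observation only.

The step changes both the substituent and its place on the phenyl ring at once, so the compounds shown do not tell whether the higher number goes with the bromine, with the new place, or with the loss of the methoxy group. From the compounds shown here alone, how an unsubstituted phenyl, a chlorophenyl or an aminophenyl would read on this carbonyl carbon with the core of compound 3 also stays open.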